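The source may hold more compounds than are shown below. What is called first, only, known or untested is meant among the compounds shown, and "the series" means these compounds.

Compound 1 `O=C(O)C[C@H]1CC[C@H](c2ccc(C(=O)Nc3nnc(Cc4ccc(F)cc4)s3)cc2)CC1`: < 2000 nM
Compound 2 `NC(=O)C[C@H]1CC[C@H](c2ccc(C(=O)Nc3nnc(Cc4ccccc4)s3)cc2)CC1`: < 2000 nM

Both compounds were tested in a physicochemical assay for solubility, read by HPLC, in phosphate buffer, with a stated time of 20 h, at pH 7.4; a lower number here means a less soluble compound, a higher number a more soluble compound. Compound 2 gives < 2000 nM, which is a limit of the assay and not a number. Compound 1 gives < 2000 nM, which is also a limit. The two results together come to the limit of < 2000 nM in this assay, at which 2 of the 2 values shown sit. The position of compound 2 is therefore known only as a limit, and no exact value is available as a starting point.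

The next compound, compound 3 `CC(C)(O)CNC(=O)C[C@H]1CC[C@H](c2ccc(C(=O)Nc3nnc(Cc4ccccc4)s3)cc2)CC1`, has 2-hydroxy-2-methylpropyl in place of hydrogen on an amide-type nitrogen. Among the compounds with values here, no step between two measured compounds is available to show how large such a change might be in this assay. The expectation therefore rests only on compound 2 with its limit of < 2000 nM. No step beyond the usual scatter is expected, and no direction can be firmly predicted. The estimated change is a step that the limit leaves unreadable from compound 2 to compound 3. A further limit is the most likely result. For compound 3 the expected value is 1500 nM, with an estimated range from 400 nM to 6000 nM.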

Compound 3, solubility: < 2000 nM
Compound 3 ended at the assay's limit; the forecaster's own chance of this, stated with the estimate: 70%; the middle value does not contradict the limit.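

In this assay, within the data shown here, compound 2 and compound 3 both end at a limit and not at a number, so no step from one to the other can be read: the limit of < 2000 nM in this assay, at which 3 of the 3 values shown sit.

The compounds shown leave open how soluble each one actually is, and whether 2-hydroxy-2-methylpropyl in place of hydrogen on an amide-type nitrogen changes the read-out at all.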